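This account rests on a few compounds, and the source may have more. Where it says the series, first, only, none or still open, it means among the compounds named here.

Three compounds of one shared core have been examined in an assay on isolated protein for inhibition of RAC-alpha serine/threonine-protein kinase (Homo sapiens), tested at 30 uM; a higher number here means more inhibition at the concentration tested (going by the name of the read-out), a lower number less inhibition. Compound 1 `Fc1ccc(Sc2ncnc3[nH]cnc23)cc1` gives 0% in this assay. Compound 2 `Cn1cnc2c(Sc3ccccc3)ncnc21` gives 0% in this assay. Compound 3 `c1ccc(CSc2ncnc3[nH]cnc23)cc1` gives 4% in this assay, a number that differs from those of compound 1 and compound 2 only within the usual scatter of such measurements, so none of the three can be set apart from the others on these numbers.

The account now turns to compound 4 `Cn1cnc2c(SCc3ccccc3)ncnc21`, which has not yet been measured. Compound 4 differs from compound 3 in one place: methyl in place of hydrogen on an aromatic nitrogen. Within the data shown here, no step between two measured compounds has been worked out, so the expectation for compound 4 rests only on the three values already in hand. Since all three lie close to zero, and compound 2, which also carries a methyl on a ring nitrogen of the shared core, gives 0%, the step of a number 2 percentage points lower from compound 3 to compound 4 (within the scatter) is expected to be none beyond the scatter. Compound 4 is therefore estimated at 2% in this assay, within a range from 0% to 12%.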

Compound 4, a percentage reported as inhibition, at one concentration (the size of the read-out at that concentration, not a potency): 4%
Beside the measured number, compound 4's estimate is 2 percentage points below it, and the stated range covers the measured number.
By their numbers in this assay, from the lowest: compounds 1, 2, 3 and 4 (each within the scatter of the next).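

In this assay, among these compounds, methyl in place of hydrogen on an aromatic nitrogen of the five-membered ring gives no change at the digits printed from compound 3 to compound 4 (within the scatter), the only step so far between measured compounds that differ in one place. At this position, then, the hydrogen and the methyl cannot be told apart on these numbers: compound 3 gives 4% and compound 4 gives 4%, both small values, so the step was read where there is very little inhibition to lose. No measurement is available that would explain this result.

From the compounds shown here alone, it remains open whether the same change would also leave the number unmoved in a compound with clearly greater inhibition. Going by these compounds, it is also open whether an ethyl group, a longer chain or a chain ending in an amine on this nitrogen would behave as methyl does.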